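A few compounds are considered here, and "the series" means these few. Any claim that something is new, unique, unknown or untested is made for them only; others in the source may bear on it.

Series notes. Compound 1 `O=C(Nc1cccc(-c2oc3cc(-c4ccc(F)cc4)ccc3c(=O)c2O)c1)c1ccccc1F` is measured in a functional assay on A549 cells (Homo sapiens) for antiproliferative activity, read by CCK-8 assay, with a stated time of 72 h (a lower number here means a stronger inhibitor, a higher number a weaker inhibitor), at 4410 nM. Compound 2 `Cc1ccccc1C(=O)Nc1cccc(-c2oc3cc(-c4ccc(F)cc4)ccc3c(=O)c2O)c1` gives 17600 nM in this assay, and compound 3 `COc1cc(OC)cc(C(=O)Nc2cccc(-c3oc4cc(-c5ccc(F)cc5)ccc4c(=O)c3O)c2)c1` gives 2390 nM. Among these three numbers compound 1 stands second highest: its nearest neighbour is compound 3, reached by a 1.8-fold lower number from compound 1 to compound 3 (0.27 log units; within the scatter), and the furthest is compound 2, reached by a 4.0-fold higher number from compound 1 to compound 2 (0.60 log units; beyond the scatter).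

Compound 4 `O=C(Nc1cccc(-c2oc3cc(-c4ccc(F)cc4)ccc3c(=O)c2O)c1)c1cnc(Cl)nc1Cl` has not yet been measured in this assay. Relative to compound 1 the change is 2,4-dichloropyrimidin-5-yl in place of 2-fluorophenyl on a carbonyl carbon. Two measured steps alter the same group on the carbonyl carbon: a 1.8-fold lower number from compound 1 to compound 3 (0.27 log units; within the scatter) and a 7.4-fold lower number from compound 2 to compound 3 (0.87 log units; beyond the scatter). Within that ring, a 4.0-fold higher number from compound 1 to compound 2 (0.60 log units; beyond the scatter) shows that a single substituent swap can move the number beyond the scatter. Within the data shown here, no measured step introduces a ring with hetero atoms or a chlorine-bearing group, so the direction of the step to compound 4 cannot be read from the three compounds; the measured spread suggests a step of modest size at most in this assay, in either direction. Compound 4 is therefore expected near compound 1, at 4000 nM, with a range from 1500 nM to 12000 nM that covers both directions. The expected step is a 1.1-fold lower number from compound 1 to compound 4 (0.04 log units; within the scatter).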

Compound 4, half-maximal inhibitory concentration: > 100000 nM
Compound 4: only a limit was reported (the forecaster's own chance of this, stated with the estimate: 5%); middle value at least 25-fold (1.39 log units) from the limit.
By their numbers in this assay, from the lowest: compounds 3 and 1 (each within the scatter of the next); then compound 2. At a limit, above all of these: compound 4.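

Replacing the substituted phenyl on the carbonyl carbon with 2,4-dichloropyrimidin-5-yl gives an at least 22-fold higher number from compound 1 to compound 4 (1.35 log units; beyond the scatter), an at least 41-fold higher number from compound 3 to compound 4 (1.62 log units; beyond the scatter) and an at least 5.6-fold higher number from compound 2 to compound 4 (0.75 log units; beyond the scatter). The reading for compound 4 in this assay is a limit and not a number: the limit of > 100000 nM in this assay, at which 1 of the 4 values shown sits. The earlier compounds shown here, all with a phenyl ring of carbon only at this place, showed steps of modest size, so this position proves far less forgiving than they suggested once the ring carries 2 hetero atoms and chlorine, and the true size of each new step stays bounded from one side only.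

The change replaces the ring atoms and the substituents together, so the compounds shown cannot say whether the ring nitrogens, the chlorines or their combination go with the loss in this assay. A 2,4-dichlorophenyl group and an unsubstituted pyrimidin-5-yl group would separate these two parts, and an amine in place of either chlorine on the pyrimidine would show whether the ring itself can be kept at this position.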